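Halogenated phenoxy tail variants in a dihydrofolate reductase series

The compounds below may be only part of what the source reports. "The series", "measured", "known", "first", "only" and "open" are said of these compounds alone.

Four compounds share one core and differ in the phenoxy tail. Compound 1 `COc1ccc(OCCCON2C(N)=NC(N)=NC23CCOCC3)cc1` and compound 2 `NC1=NC2(CCOCC2)N(OCCCOc2ccc(F)cc2)C(N)=N1` carry no number: in an assay on isolated protein for inhibition of Dihydrofolate reductase (Homo sapiens), read by spectrophotometry, using NADPH, with stated times of 5 s and 6 min, tested at 50 uM (a lower number here means a weaker effect, a higher number a stronger effect of the compound at the concentration tested), compound 1 gives "not determined" (no result reported), and compound 2 gives "not determined" (no result reported). Compound 3 `NC1=NC2(CCOCC2)N(OCCCOc2ccccc2Br)C(N)=N1` holds the only reading shown; in this assay compound 3 gives 85%, so it stands alone and no ranking among the three is possible. Compound 4 `NC1=NC2(CCOCC2)N(OCCCOc2cccc(Cl)c2)C(N)=N1` is not yet measured. It differs from compound 3 by 3-chlorophenyl in place of 2-bromophenyl on an oxygen on a saturated carbon. Among the measured compounds shown here, no measured step between halogenated tails exists in this set, so the step of a number 7 percentage points lower from compound 3 to compound 4 (within the scatter) is expected to stay within the usual scatter, with at most a slight drop. Compound 4 is estimated at 78%, with a range from 55% to 92%.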

Compound 4, a percentage reported as inhibition, at one concentration (the size of the read-out at that concentration, not a potency): 85.8%
The estimate for compound 4 lay 7.8 percentage points below the measured number; the range from low to high includes it.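

In this assay, among the compounds shown here, 3-chlorophenyl in place of 2-bromophenyl on an oxygen on a saturated carbon gives a number 0.8 percentage points higher from compound 3 to compound 4 (within the scatter), the first readable step. Two halogenated tails therefore read alike at this single test concentration, which does not show whether their potencies match. No measurement shown bears on why the two tails read alike.

Steps involving compound 1 and compound 2 cannot be read. Still open, from the compounds shown here alone, is whether a phenyl tail carrying an amine or a carboxylic acid, or a longer chain, would depart from this reading.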